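The compounds below may be only part of what the source reports. "The series", "measured", "known", "first", "only" and "open" are said of these compounds alone.

Measured compounds:
compound 1 `NC1=NC2(CCSCC2)N(OCCCOc2ccc(Br)cc2)C(N)=N1` — in an assay on isolated protein for inhibition of Dihydrofolate reductase (Homo sapiens), read by spectrophotometry, using NADPH, with stated times of 5 s and 6 min, tested at 5 uM (on this read-out lower numbers stand for a weaker effect and higher numbers for a stronger effect at the one concentration tested), compound 1 gives > 90%, a limit of the assay.
compound 2 `NC1=NC2(CCOCC2)N(OCCCOc2ccc(F)cc2)C(N)=N1` — in this assay compound 2 gives > 90%, likewise a limit.
compound 3 `NC1=NC2(CCSCC2)N(OCCCOc2ccccc2Br)C(N)=N1` — in this assay compound 3 gives 88.7%.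

Compound 2 thus stands at the limit of > 90% in this assay, at which 2 of the 3 values shown sit; its reading is a limit, not a number. Compound 4 `NC1=NC2(CCOCC2)N(OCCCOc2cccc(Cl)c2)C(N)=N1` is not yet measured. The change is 3-chlorophenyl in place of 4-fluorophenyl on an oxygen on a saturated carbon. Within the data shown here, the one measured step at this place, a number at least 1.3 percentage points lower from compound 1 to compound 3 (that floor lies within the scatter), stays within the scatter, so no step beyond the scatter is expected for the change at hand either. With compound 2 at the limit, compound 4 is expected to sit at or just under it. The estimate for compound 4 is 89%, ranging from 80% to 95%. The expected step is a number at least 1 percentage points lower from compound 2 to compound 4 (that floor lies within the scatter).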

Compound 4, a percentage reported as inhibition, at one concentration (the size of the read-out at that concentration, not a potency): 83.2%
Compound 4: the middle estimate sits 5.8 percentage points above what was measured, and the stated range covers the measured number.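

In this assay the change reads a number at least 6.8 percentage points lower from compound 2 to compound 4 (that floor lies within the scatter), and that floor is all that can be said of its size because compound 2 sits at a limit: the limit of > 90% in this assay, at which 2 of the 4 values shown sit. The core of compound 2 now also carries a number under the limit, so such a reading is no longer confined to the core of compound 1. Among the compounds shown, 4-bromophenyl and 4-fluorophenyl sit at the limit while 2-bromophenyl and 3-chlorophenyl give numbers, and none goes against this.

Going by these compounds, since halogen and ring position change together here, their separate contributions stay open. On these data alone, how an amine or a carboxylic acid on the phenyl ring would read also stays open.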